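A few compounds are considered here, and "the series" means these few. Any claim that something is new, unique, unknown or untested is made for them only; others in the source may bear on it.

Compound 1 `O=C(Nc1ccccc1Cl)N1CCC(c2nc(-c3ccc4ccccc4n3)no2)CC1`: 510 nM
Compound 2 `O=C(NC1CCCCC1)N1CCN(c2nc(-c3ccc4ccccc4n3)no2)CC1`: 53 nM
Compound 3 `O=C(NC1CCNCC1)N1CCC(c2nc(-c3ccc4ccccc4n3)no2)CC1`: 2500 nM

In a functional assay on Shh Light II cells (Mus musculus) for inhibition, read by a luciferase reporter (a lower number here means a stronger inhibitor, a higher number a weaker inhibitor), compound 3 stands highest of the three numbers. The nearest number is that of compound 1. Among the measured compounds shown here, the single change separating the two reads a 4.9-fold higher number from compound 1 to compound 3 (0.69 log units; beyond the scatter), through piperidin-4-yl in place of 2-chlorophenyl on an amide-type nitrogen, a modest step beyond the scatter. The lowest number belongs to compound 2, which differs from compound 3 in more than one place, so only the two values themselves can be set side by side.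

Compound 4 `O=C(NC1CCS(=O)(=O)CC1)N1CCC(c2nc(-c3ccc4ccccc4n3)no2)CC1` carries the next change: 1,1-dioxothian-4-yl in place of piperidin-4-yl on an amide-type nitrogen. For the measured compounds named here, the one measured step at this position is the one already described, and it shows that the group on the amide-type nitrogen moves the number by a modest amount. Going by the values given here, no measured step exchanges piperidin-4-yl for 1,1-dioxothian-4-yl, so the expectation rests on that spread alone. For compound 4 the expected step is a 2.8-fold lower number from compound 3 to compound 4 (0.44 log units; beyond the scatter). Compound 4 is therefore estimated at 900 nM, within a range from 250 nM to 3500 nM.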

Compound 4, half-maximal inhibitory concentration: 360 nM
For compound 4 the middle estimate is 2.5-fold (0.40 log units) above the measured one, within the range that was stated.
By their numbers in this assay, from the lowest: compound 2; then compounds 4 and 1 (each within the scatter of the next); then compound 3.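

In this assay, exchanging piperidin-4-yl for 1,1-dioxothian-4-yl gives a 6.9-fold lower number from compound 3 to compound 4 (0.84 log units; beyond the scatter), so two six-membered non-aromatic rings on the amide-type nitrogen, each with one hetero atom, can still read apart beyond the scatter. The second comparison, a 1.4-fold lower number from compound 1 to compound 4 (0.15 log units; within the scatter), lies within the scatter, which leaves 1,1-dioxothian-4-yl and 2-chlorophenyl indistinguishable at this position, and the group that stands apart among these three is piperidin-4-yl. Nothing available explains why the number moves with this exchange.

The compounds shown leave open how oxan-4-yl, whose ring holds a single oxygen, or N-acetylpiperidin-4-yl would read on the amide-type nitrogen. Among the compounds shown here, they also leave open how cyclohexyl, seen only on the core of compound 2, would read on the core of compound 3.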